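Taking one methoxy off compound 3

A few compounds are considered here, and "the series" means these few. Any claim that something is new, unique, unknown or untested is made for them only; others in the source may bear on it.

In a functional assay, read by spectrophotometry, with a stated time of 5 min (on this read-out lower numbers stand for stronger inhibition and higher numbers for weaker inhibition), compound 1 `COc1cc(/C=C/C(=O)C(=Cc2ccc(OC)c(OC)c2)C(=O)/C=C/c2ccc(O)c(OC)c2)ccc1O` gives 6760 nM, compound 2 `CCOc1cc(C=C(C(=O)/C=C/c2ccc(O)c(OC)c2)C(=O)/C=C/c2ccc(O)c(OC)c2)ccc1O` gives 3980 nM and compound 3 `CCOc1cc(/C=C/C(=O)C(=Cc2ccc(O)c(OC)c2)C(=O)/C=C/c2ccc(O)c(OCC)c2)ccc1O` gives 5360 nM. These three numbers all lie within the usual scatter of one another, so compound 3 cannot be ranked against the other two. Compound 4 `CCOc1cc(/C=C/C(=O)C(=Cc2ccc(O)cc2)C(=O)/C=C/c2ccc(O)c(OCC)c2)ccc1O` has not yet been measured. It differs from compound 3 by hydrogen in place of methoxy on an aromatic carbon, so a 4-hydroxy-3-methoxyphenyl becomes a 4-hydroxyphenyl: hydrogen in place of methoxy on an aromatic carbon. Among the compounds with values here, only one measured step offers any guide, a 1.7-fold lower number from compound 1 to compound 2 (0.23 log units; within the scatter). That step puts 3-ethoxy-4-hydroxyphenyl in place of 3,4-dimethoxyphenyl, so it is a different change, and it stays within the scatter. Within the data shown here, no measured step removes a methoxy outright, which leaves the direction open. The expected result is a 1.1-fold higher number from compound 3 to compound 4 (0.05 log units; within the scatter), meaning no shift beyond the scatter. For compound 4 the estimated value in this assay is 6000 nM, with an expected range of 2500 nM to 14000 nM.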

Compound 4, half-maximal inhibitory concentration: 14800 nM
Compound 4: middle estimate off by 2.5-fold (0.39 log units), on the low side, outside the stated range (above it).
By their numbers in this assay, from the lowest: compounds 2, 3 and 1 (each within the scatter of the next); then compound 4.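

Of the two steps read so far in this assay, only this one lies beyond the scatter: hydrogen in place of methoxy gives a 2.8-fold higher number from compound 3 to compound 4 (0.44 log units; beyond the scatter), a modest loss of inhibition. The swap from 3,4-dimethoxyphenyl to 3-ethoxy-4-hydroxyphenyl between compound 1 and compound 2 stayed within the scatter, so this ring tolerated that exchange of groups but not the outright loss of the methoxy. No measurement here explains why the methoxy counts.

The compounds shown compare only methoxy and hydrogen in a single step at this place, so it remains unclear whether any group there would serve as well. A fluorine, an amine or a longer chain such as propoxy on this aromatic carbon would test that.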